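The compounds below may be only part of what the source reports. "The series", "measured", "known", "first", "only" and "open" are said of these compounds alone.

The study set three measured compounds against an ADME assay on LLC-MK2 cells (Macaca mulatta) for cytotoxicity, read by spectrophotometry and crystal violet staining, with a stated time of 4 days; on this read-out lower numbers stand for higher toxicity in this test and higher numbers for lower toxicity in this test. Compound 1 `CC(C)n1ncc2c(C(=O)Nc3cc(S(N)(=O)=O)ccc3F)cc(-c3cccs3)nc21` gives 25000 nM in this assay, compound 2 `CC(C)n1ncc2c(C(=O)Nc3cccc(F)c3F)cc(-c3cccs3)nc21` gives 75000 nM, and compound 3 `CNS(=O)(=O)c1cccc(NC(=O)c2cc(-c3cccs3)nc3c2cnn3C(C)C)c1` gives 25000 nM. Compound 3 is level with compound 1 at the digits shown, the two together the lowest of the three numbers, while compound 2 sits at a higher number, a gap beyond the scatter. Compound 4 `CC(C)n1ncc2c(C(=O)Nc3cccc(S(N)(=O)=O)c3)cc(-c3cccs3)nc21` has not yet been measured. It differs from compound 3 in one place: hydrogen in place of methyl on a sulfonamide nitrogen. Within the data shown here, no measured pair spans this change, so the expectation rests on compounds 1 and 3, which both carry a sulfonamide and sit together. The step is expected as no change at the digits printed from compound 3 to compound 4 (within the scatter), none beyond the scatter. Compound 4 is therefore estimated at 25000 nM, within a range from 12000 nM to 60000 nM.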

Compound 4, half-maximal cytotoxic concentration: 25000 nM
Compound 4: middle estimate and measured number agree at the digits printed; measured number inside the range.
By their numbers in this assay, from the lowest: compounds 1, 3 and 4 (each within the scatter of the next); then compound 2.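

In this assay the methyl on the sulfonamide nitrogen proves dispensable: the step reads no change at the digits printed from compound 3 to compound 4 (within the scatter), and hydrogen in place of fluoro on an aromatic carbon likewise gives no change at the digits printed from compound 1 to compound 4 (within the scatter). Among these compounds, the one step here beyond the scatter is a 3.0-fold lower number from compound 2 to compound 4 (0.48 log units; beyond the scatter), with 3-sulfamoylphenyl in place of 2,3-difluorophenyl on an amide-type nitrogen. Nothing available accounts for these steps. The compounds shown leave open whether a longer chain on the sulfonamide nitrogen, or an amine or carboxylic acid in place of the sulfamoyl group, would stay at this level.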